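The source may report more compounds than this note shows. Statements on the series, on what has been measured and on what is new or still open speak of the compounds shown alone.

Compound 2 `COc1ccc(-c2cn(C)c(=O)c3[nH]c(C(=O)NCc4ccc(C(=O)Nc5ccccc5N)cc4)cc23)cc1` gives 320 nM in a functional assay on MV4-11 cells (Homo sapiens) for antiproliferative activity, read by CCK-8 assay, with a stated time of 72 h (on this read-out lower numbers stand for stronger inhibition and higher numbers for weaker inhibition), the highest of the two numbers in hand; its nearest neighbour is compound 1 `CC(C)Oc1ccccc1-c1cn(C)c(=O)c2[nH]c(C(=O)NCc3ccc(C(=O)Nc4ccccc4N)cc3)cc12`, which in this assay gives 130 nM. Going by the values given here, the only measured step, a 2.5-fold higher number from compound 1 to compound 2 (0.39 log units; beyond the scatter), changes the group on the same aromatic carbon that is altered in compound 3 `Cn1cc(-c2cccc(F)c2)c2cc(C(=O)NCc3ccc(C(=O)Nc4ccccc4N)cc3)[nH]c2c1=O`, where the change is 3-fluorophenyl in place of 4-methoxyphenyl on an aromatic carbon. Among the compounds with values here, that single step shows a modest movement from exchanging one aryl group for another, so a shift of similar scale is plausible, but nothing in hand indicates the direction for a 3-fluorophenyl group, which has no counterpart among the measured compounds. Compound 3 is therefore expected to show only a small step, a 1.3-fold lower number from compound 2 to compound 3 (0.11 log units; within the scatter), in this assay, with wide uncertainty either way. The estimate for compound 3 in this assay is 250 nM, ranging from 90 nM to 700 nM.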

Compound 3, half-maximal inhibitory concentration: 210 nM
Estimate against measurement, compound 3: 1.2-fold (0.08 log units) above; the measured number falls inside the stated range.
By their numbers in this assay, from the lowest: compounds 1, 3 and 2 (each within the scatter of the next, the first and the last beyond it).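

In this assay, the step to the 3-fluorophenyl group is a 1.5-fold lower number from compound 2 to compound 3 (0.18 log units; within the scatter), and the step from the other aryl group is a 1.6-fold higher number from compound 1 to compound 3 (0.21 log units; within the scatter), so both stay within the scatter. This aromatic carbon therefore carries an aryl group without oxygen and with no hydrogen-bond acceptor, and the number stays in the range of the two alkoxy-bearing aryl groups, even though those two differ from each other beyond the scatter. Nothing available explains how these aryl groups relate to their numbers.

The compounds shown leave open whether 2-fluorophenyl or 4-fluorophenyl would read like 3-fluorophenyl, and whether the 2-isopropoxyphenyl number depends on the isopropoxy group or on its place on the ring. They also leave open how a pyridine ring, an unsubstituted phenyl or an amine would behave on this carbon.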